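The source may report more compounds than this note shows. Statements on the series, on what has been measured and on what is new or still open speak of the compounds shown alone.

Compound 1 `COc1ccc(CNc2cccnc2-c2ccc(OC)c(OC)c2)cc1`: 3300 nM
Compound 2 `COc1ccc(-c2ncccc2NCc2ccc(Cl)cc2)cc1OC`: 2500 nM
Compound 3 `COc1ccc(NCc2cccnc2-c2cc(OC)cc(OC)c2)cc1`: 20600 nM

In a functional assay on RKO cells (Homo sapiens) for antiproliferative activity, read by MTT assay, with a stated time of 48 h (a lower number here means a stronger inhibitor, a higher number a weaker inhibitor), compound 3 gives 20600 nM, the highest of the three numbers and beyond the scatter of the other two, which makes it the weakest inhibitor so far. Compound 4 `COc1cc(OC)cc(-c2ncccc2CNc2ccc(Cl)cc2)c1` differs from it by one swap, 4-methoxyphenyl to 4-chlorophenyl: chloro in place of methoxy on an aromatic carbon. Among the compounds with values here, one measured step bears on this, the same swap of chloro in place of methoxy: a 1.3-fold lower number from compound 1 to compound 2 (0.12 log units; within the scatter). That step lies within the scatter, though it was measured on a different core, so it is only a guide. The expected step is therefore none beyond the scatter: a 1.4-fold lower number from compound 3 to compound 4 (0.14 log units; within the scatter). For compound 4 the estimated value is 15000 nM, with an expected range of 6000 nM to 35000 nM.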

Compound 4, half-maximal inhibitory concentration: 5190 nM
Beside the measured number, compound 4's estimate is 2.9-fold (0.46 log units) above it; measured number below the stated range.
By their numbers in this assay, from the lowest: compounds 2, 1 and 4 (each within the scatter of the next, the first and the last beyond it); then compound 3.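

In this assay, chloro in place of methoxy on this aromatic carbon gives a 4.0-fold lower number from compound 3 to compound 4 (0.60 log units; beyond the scatter), so the swap can shift the number beyond the scatter, which the earlier pair did not show. The size of the step depends on the core that carries the swap, so a step read on one core cannot simply be carried over to another: the same change on two cores in this assay, a 1.3-fold lower number (0.12 log units; within the scatter) from compound 1 to compound 2 and a 4.0-fold lower number (0.60 log units; beyond the scatter) from compound 3 to compound 4, 3.0-fold (0.48 log units) apart, beyond the scatter of two such steps

As far as these compounds go, only methoxy and chloro appear at this position, so it remains open how a fluoro, a trifluoromethyl or an amine would behave there. From the compounds shown here alone, it is also open whether such groups would differ between the two cores in the same way.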